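This account rests on a few compounds, and the source may have more. Where it says the series, first, only, none or still open, it means among the compounds named here.

Compound 1 `CC/C=C\C[C@H]1C(=O)C=C[C@H]1CC(=O)OCCCCC` is the starting point of this account. Going by the values given here, in an ADME assay on RAW264.7 cells (Mus musculus) for cytotoxicity, read by MTT assay, with a stated time of 24 h (a higher number here means that more compound is tolerated, a lower number that less compound is tolerated), compound 1 gives 37 uM, the lowest of the two numbers measured so far; its nearest neighbour is compound 2 `CC/C=C\C[C@H]1C(=O)C=C[C@H]1CC(=O)Oc1ccccc1`, which in this assay gives 158 uM. Among the compounds with values here, the one measured step is a 4.3-fold higher number from compound 1 to compound 2 (0.63 log units; beyond the scatter), a modest rise that lies beyond the scatter.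

Compound 3 `CC/C=C\C[C@H]1C(=O)C=C[C@H]1CC(=O)OCCOCCOCCO` has not yet been measured in this assay. It differs from compound 1 as follows: 2-(2-hydroxyethoxy)ethoxy in place of propyl on a saturated chain carbon, two bonds along the chain from an oxygen next to a carbonyl group. Within the data shown here, the only measured step that bears on this change is the one from compound 1 to compound 2, since both alter what hangs from the oxygen of the ester, and that step was modest. The new group in compound 3 is neither a phenyl nor a plain chain, so the step is read as a weak pointer only. For compound 3 a small rise is therefore expected, about a 1.6-fold higher number from compound 1 to compound 3 (0.21 log units; within the scatter), but not one that is clearly beyond the scatter. Compound 3 is estimated at 60 uM, with a range of 25 uM to 150 uM.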

Compound 3, half-maximal toxic concentration: 162 uM
Compound 3: the middle estimate sits 2.7-fold (0.43 log units) below what was measured; the measured number lies above the stated range.
By their numbers in this assay, from the lowest: compound 1; then compounds 2 and 3 (each within the scatter of the next).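

Replacing propyl with 2-(2-hydroxyethoxy)ethoxy on a saturated chain carbon, two bonds along the chain from an oxygen next to a carbonyl group, gives in this assay a 4.4-fold higher number from compound 1 to compound 3 (0.64 log units; beyond the scatter), so this position responds to an open chain as well as to the phenyl of compound 2. Compound 2 at 158 uM and compound 3 at 162 uM lie within the scatter of each other, which shows that, among these three compounds, a ring on the ester oxygen is not needed for a number of this size. Nothing available here explains why the number changes with either group.

As far as these compounds go, what remains open is which part of the 2-(2-hydroxyethoxy)ethoxy group goes with the rise: its chain length, its ether oxygens or its hydroxy group, since all of these enter together in compound 3. A longer plain alkyl chain would bear on the first of these, while an amine or a carboxylic acid in place of the hydroxy group would bear on the last.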